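A few compounds are considered here, and "the series" means these few. Any claim that something is new, unique, unknown or untested is made for them only; others in the source may bear on it.

Measured compounds:
- Compound 2, `O=[N+]([O-])c1ccccc1-c1nc(NCc2ccc(-c3cccnc3)cc2)c2ccccc2n1`, gives 7800 nM in an assay on a protein complex for inhibition of ubiquitin carboxyl-terminal hydrolase 1/WD repeat-containing protein 48 (Homo sapiens), read by fluorescence; on this read-out higher numbers stand for weaker inhibition and lower numbers for stronger inhibition.
- Compound 1, `FC(F)(F)c1cc(-c2ccc(CNc3nc(-c4ccccc4C(F)(F)F)nc4ccccc34)cc2)ccn1`, gives 4900 nM in this assay.

Compound 2 and compound 1 lie within the scatter of each other, so neither can be called the stronger inhibitor. Compound 3, `FC(F)c1ccccc1-c1nc(NCc2ccc(-c3cccnc3)cc2)c2ccccc2n1`, has not been measured; it differs from compound 2 by difluoromethyl in place of nitro on an aromatic carbon. Going by the values given here, no like-for-like step for this change exists among the measured compounds, so any expectation rests only on compound 1 and compound 2. A step of little size is expected, if anything toward a lower number, as a 1.6-fold lower number from compound 2 to compound 3 (0.19 log units; within the scatter). Compound 3 is estimated at 5000 nM, within 2000 nM to 15000 nM.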

Compound 3, half-maximal inhibitory concentration: 1400 nM
The estimate for compound 3 lay 3.6-fold (0.55 log units) above the measured number; the whole stated range lies above it.
By their numbers in this assay, from the lowest: compound 3; then compounds 1 and 2 (each within the scatter of the next).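

In this assay, difluoromethyl in place of nitro gives a 5.6-fold lower number from compound 2 to compound 3 (0.75 log units; beyond the scatter), which shows that this position, ortho to a large group, responds to the group it carries; compound 1 and compound 2 differ in more than one place and could not show this. The entering group has no hydrogen-bond acceptors, so acceptors on this group are not needed for the inhibition seen with compound 3.

Nothing measured here explains the size of this step. As far as these compounds go, whether a nitrile or an amine at this position would give a lower or a higher number than compound 3 remains open.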